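This account rests on a few compounds, and the source may have more. Where it says the series, first, only, none or still open, it means among the compounds named here.

In a functional assay on HT-1080 cells (Homo sapiens), read by transwell migration, with a stated time of 24 h, tested at 1 uM (a higher number here means a weaker effect of the compound at the concentration tested, a lower number a stronger effect), compound 1 `CC(=O)OCc1ccc2oc(=O)c(C(=O)Oc3cccc(Cl)c3)cc2c1` gives 49.1%. Compound 2 `CCCCC(=O)OCc1ccc2oc(=O)c(C(=O)Oc3cccc(Br)c3)cc2c1` gives 63.3%, the highest of the two numbers, with compound 1 sitting lower by a margin beyond the usual scatter. Compound 3 `NCc1ccc2oc(=O)c(C(=O)Oc3cccc(Br)c3)cc2c1` has not yet been measured; it differs from compound 2 in one place: amino in place of (butylcarbonyl)oxy on a saturated chain carbon bound to an aromatic carbon. Among the measured compounds shown here, no measured pair shows what this change does, so its direction is open. The step expected here is a number 5.3 percentage points lower from compound 2 to compound 3 (within the scatter), a small shift that may not exceed the scatter. Compound 3 is expected to give 58%, within a range from 32% to 84%.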

Compound 3, a percentage reported as activity, at one concentration (the size of the read-out at that concentration, not a potency): 79.3%
Estimate against measurement, compound 3: 21.3 percentage points below; the measured number falls inside the stated range.
By their numbers in this assay, from the lowest: compound 1; then compound 2; then compound 3.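

Putting amino in place of (butylcarbonyl)oxy on a saturated chain carbon bound to an aromatic carbon gives, in this assay, a number 16 percentage points higher from compound 2 to compound 3 (beyond the scatter). This position is therefore not indifferent to its substituent, and here the change goes toward a weaker effect at the concentration tested. No available evidence explains this shift.

Among the compounds shown here, the single step cannot separate losing (butylcarbonyl)oxy from gaining amino. As far as these compounds go, how a hydroxyl or an acetamide on that carbon would compare remains open.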